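This account rests on a few compounds, and the source may have more. Where it says the series, first, only, none or still open, it means among the compounds named here.

Compound 2 `CC1=C(C(=O)Nc2ccc(F)c(Cl)c2)C(c2cccc(Oc3ccccc3)c2)NC(=S)N1` gives the lowest of the two numbers recorded in a functional assay on PC-3 cells (Homo sapiens) for cytotoxicity, read by sulforhodamine B assay, with a stated time of 48 h; a lower number here means a stronger inhibitor of growth, a higher number a weaker inhibitor of growth: compound 2 gives 12000 nM, while compound 1 `CC1=C(C(=O)Nc2ccc(F)c(Cl)c2)C(c2cccc(Cl)c2)NC(=S)N1` gives 25100 nM. Going by the values given here, the only step measured so far, a 2.1-fold lower number from compound 1 to compound 2 (0.32 log units; beyond the scatter), is modest. Compound 3 `CC1=C(C(=O)Nc2ccc(F)c(Cl)c2)C(c2cccc(O)c2)NC(=S)N1` is reached from compound 2 by hydrogen in place of phenyl on an oxygen on an aromatic ring, so that the phenoxy group that set compound 2 apart from compound 1 is cut back to hydroxy. Among the compounds with values here, no measured step concerns this exact change, and the one step that bears on it, a 2.1-fold lower number from compound 1 to compound 2 (0.32 log units; beyond the scatter), suggests that the phenyl part of the phenoxy group carried a modest share of the difference between compound 1 and compound 2. Compound 3 is therefore expected to show a modestly higher number than compound 2 in this assay, as a 1.8-fold higher number from compound 2 to compound 3 (0.26 log units; within the scatter). Compound 3 is estimated at 22000 nM, within a range from 9000 nM to 55000 nM.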

Compound 3, concentration for 50% growth inhibition: 25100 nM
Beside the measured number, compound 3's estimate is 1.1-fold (0.06 log units) below it; the range from low to high includes it.
By their numbers in this assay, from the lowest: compound 2; then compounds 1 and 3 (each within the scatter of the next).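

At this position, this assay shows that the lower number of the phenoxy compound depends on the phenyl group and not on the oxygen alone: removing that phenyl gives a 2.1-fold higher number from compound 2 to compound 3 (0.32 log units; beyond the scatter) in this series. Hydroxy and chloro on this aromatic carbon cannot be told apart, with no change at the digits printed from compound 1 to compound 3 (within the scatter) between them, so among the three groups compared only phenoxy stands apart. Nothing available explains why the phenyl group matters here.

The three compounds do not settle whether the lower number requires an aromatic ring on the oxygen or merely a larger group, a question that methoxy, benzyloxy or a longer alkoxy chain would address. From the compounds shown here alone, it also remains open how an amine or a carboxylic acid at this place, or a substituent on the phenyl ring of the phenoxy group, would compare.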